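Two Hydroxyls on the Benzoyl Ring

The source may report more compounds than this note shows. Statements on the series, on what has been measured and on what is new or still open speak of the compounds shown alone.

Two compounds have been measured in a functional assay, with a stated time of 30 min; a higher number here means a weaker inhibitor, a lower number a stronger inhibitor:
Compound 1 `COc1ccc(C2CC(=NOC(=O)c3ccccc3)CC(c3ccc(OC)cc3)N2C)cc1` gives 375000 nM.
Compound 2 `COc1ccc(C2CC(=NOC(=O)c3ccccc3OC(C)=O)CC(c3ccc(OC)cc3)N2C)cc1` gives 350000 nM.

Compound 1 has the highest of the two numbers, but compound 2 sits within the scatter of it. Compound 3 `COc1ccc(C2CC(=NOC(=O)c3cc(O)cc(O)c3)CC(c3ccc(OC)cc3)N2C)cc1` is not yet measured; it differs from compound 1 by 3,5-dihydroxyphenyl in place of phenyl on a carbonyl carbon. For the measured compounds named here, the only measured step also alters this same aromatic ring, and it was a 1.1-fold lower number from compound 1 to compound 2 (0.03 log units; within the scatter). On that basis a step of a 1.2-fold lower number from compound 1 to compound 3 (0.07 log units; within the scatter) is expected, with no change beyond the scatter. Compound 3 is therefore estimated at 320000 nM, between 120000 nM and 900000 nM.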

Compound 3, half-maximal inhibitory concentration: 19000 nM
Compound 3: middle estimate off by 17-fold (1.23 log units), on the high side; measured number outside the range, below it.
By their numbers in this assay, from the lowest: compound 3; then compounds 2 and 1 (each within the scatter of the next).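

In this assay 3,5-dihydroxyphenyl on this carbonyl carbon brings a 20-fold lower number from compound 1 to compound 3 (1.30 log units; beyond the scatter) against phenyl and an 18-fold lower number from compound 2 to compound 3 (1.27 log units; beyond the scatter) against 2-acetoxyphenyl, so changing this ring can move the number strongly, which the acetoxy step, within the scatter, did not show. Nothing measured here explains why this change has so large an effect. It remains open whether both hydroxyl groups are needed, since 3-hydroxyphenyl does not appear among these compounds, and whether 3,5-dimethoxyphenyl or 3,5-diaminophenyl would give a similar number.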